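This account rests on a few compounds, and the source may have more. Where it says the series, first, only, none or still open, it means among the compounds named here.

In a functional assay on V79 cells (Cricetulus griseus) for cytotoxicity, read by colony formation (a higher number here means a weaker inhibitor, a lower number a stronger inhibitor), compound 2 (`O=C(O)c1cn(C2CC2)c2c(Cl)c(N3CCCC3)c(F)cc2c1=O`) gives 150 ug/mL and sits at the high end of the series with compound 3 (`O=C(O)c1cn(C2CC2)c2c(C(F)(F)F)c(N3CCCC3)c(F)cc2c1=O`) at 280 ug/mL, the two lying within the scatter (a 1.9-fold higher number from compound 2 to compound 3 (0.27 log units; within the scatter)). Compound 1 (`O=C(O)c1cn(C2CC2)c2cc(N3CCCC3)c(F)cc2c1=O`) gives 38 ug/mL, well clear of both. Compound 4 (`NCC1CCN(c2c(F)cc3c(=O)c(C(=O)O)cn(C4CC4)c3c2Cl)C1`) differs from compound 2 by aminomethyl in place of hydrogen on a saturated ring carbon. Going by the values given here, no measured step touches that ring. Among the compounds with values here, the only guides are the modest steps on an aromatic carbon, a 3.9-fold higher number from compound 1 to compound 2 (0.60 log units; beyond the scatter) and a 7.4-fold higher number from compound 1 to compound 3 (0.87 log units; beyond the scatter), which give a size but no direction. A modest move towards a lower number is expected, on thin evidence. The expected step is a 3.0-fold lower number from compound 2 to compound 4 (0.48 log units; beyond the scatter). For compound 4 the estimate is 50 ug/mL, with an expected range of 12 ug/mL to 200 ug/mL.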

Compound 4, half-maximal inhibitory concentration: 8 ug/mL
The estimate for compound 4 lay 6.3-fold (0.80 log units) above the measured number; the measured number lies below the stated range.
By their numbers in this assay, from the lowest: compound 4; then compound 1; then compounds 2 and 3 (each within the scatter of the next).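

Changing pyrrolidin-1-yl to 3-(aminomethyl)pyrrolidin-1-yl gives the largest step in the series in this assay (a 19-fold lower number from compound 2 to compound 4 (1.27 log units; beyond the scatter)). It exceeds both steps on the aromatic carbon (a 3.9-fold higher number from compound 1 to compound 2 (0.60 log units; beyond the scatter); a 7.4-fold higher number from compound 1 to compound 3 (0.87 log units; beyond the scatter)) and runs the opposite way, so the saturated ring carbon strongly affects this read-out, on the evidence of one pair. Nothing available explains the size of this step.

A methyl or hydroxymethyl group on that ring carbon would show whether the amine is needed. Also open, as far as these compounds go, is whether aminomethyl gives a similar step with hydrogen or trifluoromethyl in place of the chloro group.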